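Compound 2 to compound 3: one more methoxy

The source may report more compounds than this note shows. Statements on the series, on what has been measured and on what is new or still open speak of the compounds shown alone.

Series so far in a functional assay on HGC-27 cells (Homo sapiens) for cytotoxicity, read by MTT assay, with a stated time of 48 h; a lower number here means a stronger inhibitor, a higher number a weaker inhibitor:
- compound 1 `COc1ccc(/C=C/C(=O)/C=C/c2cc3ccccc3nc2Cl)cc1`: > 10000 nM (a limit)
- compound 2 `COc1ccc(/C=C/C(=O)/C=C/c2cc3ccccc3nc2Cl)c(OC)c1`: > 10000 nM (a limit)
- compound 3 `COc1cc(OC)c(OC)cc1/C=C/C(=O)/C=C/c1cc2ccccc2nc1Cl`: not yet measured

In this assay compound 2 gives > 10000 nM and this is a limit, not a number. Compound 3 has methoxy in place of hydrogen on an aromatic carbon. Going by the values given here, one measured step bears on this, the same kind of change: a step that the two limits leave unreadable from compound 1 to compound 2 gives no size to carry over. The series otherwise offers only the limit of > 10000 nM in this assay, at which 2 of the 2 values shown sit, as its reference point. No step beyond the scatter is therefore expected in either direction, and another limit is the likeliest report. The estimated change is a step that the limit leaves unreadable from compound 2 to compound 3 and it remains weakly founded. Compound 3 is estimated at 15000 nM with an expected range from 6000 nM to 40000 nM in this assay.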

Compound 3, half-maximal inhibitory concentration: 8730 nM
For compound 3 the middle estimate is 1.7-fold (0.24 log units) above the measured one; the measured number falls inside the stated range.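

In this assay compound 3 gives 8730 nM, the first number in the series rather than a limit: the limit of > 10000 nM in this assay, at which 2 of the 3 values shown sit.

The methoxy added here stands ortho to a methoxy group, para to a methoxy group and meta to a large group, and the result is an at least 1.1-fold lower number from compound 2 to compound 3 (0.05 log units; that floor lies within the scatter). On these data alone, this is only a floor, so the true size of the step is unknown, and the step from compound 1 to compound 2 cannot be read, which leaves no two sizes for this change to compare.

As far as these compounds go, whether a methoxy on this carbon has the same outcome without the other two methoxy groups stays open. So does the outcome of a different group on this carbon, such as a hydroxy group or an amine.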